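Swapping 3-methoxyphenyl for 4-(trifluoromethyl)phenyl

This account rests on a few compounds, and the source may have more. Where it says the series, first, only, none or still open, it means among the compounds named here.

Two measured compounds share one core and differ in a single group. In an ADME assay on Vero cells (Chlorocebus sabaeus) for cytotoxicity, read by MTT assay (on this read-out higher numbers stand for weaker inhibition and lower numbers for stronger inhibition), compound 1 `C=CCOc1cc(OC)c(C(=O)/C=C/c2ccc(F)cc2)c(OCC=C)c1` gives 13600 nM and compound 2 `C=CCOc1cc(OC)c(C(=O)/C=C/c2cccc(OC)c2)c(OCC=C)c1` gives 142000 nM as the highest of the two numbers. The change to compound 3 `C=CCOc1cc(OC)c(C(=O)/C=C/c2ccc(C(F)(F)F)cc2)c(OCC=C)c1` falls at the same place, on a double-bonded chain carbon bound to a double-bonded chain carbon (4-(trifluoromethyl)phenyl in place of 3-methoxyphenyl on a double-bonded chain carbon bound to a double-bonded chain carbon). Among the measured compounds shown here, only one measured step bears on this (a 10-fold higher number from compound 1 to compound 2 (1.02 log units; beyond the scatter)), with 3-methoxyphenyl in place of 4-fluorophenyl at that place. The new change removes that 3-methoxyphenyl again, and the entering 4-(trifluoromethyl)phenyl carries fluorine, as 4-fluorophenyl does. One step is thin evidence, and the data do not show how trifluoromethyl compares with a single fluorine. So only part of that step is expected to be undone, giving in this assay a lower number than compound 2 shows, beyond the scatter. The step expected here is a 4.1-fold lower number from compound 2 to compound 3 (0.61 log units; beyond the scatter) by this estimate. The value estimated for compound 3 is 35000 nM with 11000 nM to 110000 nM as the expected range.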

Compound 3, half-maximal inhibitory concentration: 7200 nM
Compound 3: the middle estimate sits 4.9-fold (0.69 log units) above what was measured; the whole stated range lies above it.
By their numbers in this assay, from the lowest: compounds 3 and 1 (each within the scatter of the next); then compound 2.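

In this assay, taking out 3-methoxyphenyl on a double-bonded chain carbon bound to a double-bonded chain carbon gives a 20-fold lower number from compound 2 to compound 3 (1.29 log units; beyond the scatter) and shows that a second group besides 4-fluorophenyl lies far from compound 2 on this read-out. Among these three compounds, the high number therefore belongs to compound 2 alone, while both fluorine-bearing groups give much lower numbers. Trifluoromethyl in place of fluoro on an aromatic carbon gives a 1.9-fold lower number from compound 1 to compound 3 (0.28 log units; within the scatter) and stays within the usual scatter, so this assay does not separate those two groups, and no measurement shown here accounts for the gap between them and 3-methoxyphenyl.

Compound 2 differs from the other two compounds in both the group on its ring and where that group sits, so these data cannot say which of the two goes with its high number. From the compounds shown here alone, it also remains open how this assay would read a plain phenyl ring, or a phenyl ring carrying an amine or a carboxylic acid, at this place on the shared core.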